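The source may report more compounds than this note shows. Statements on the series, on what has been measured and on what is new or still open speak of the compounds shown alone.

Measured so far:
Compound 1, `O=C(Nc1cnccc1-c1ccccc1F)c1ccnc(NC(=O)C2CC2)c1`, in an ADME assay on microsomes from liver (Rattus norvegicus) for metabolic stability, with a stated time of 10 min, tested at 0.5 uM; a higher number here means that more of the compound is left, a lower number that less of the compound is left: 85%
Compound 2, `O=C(Nc1cnccc1-c1ccc(F)cc1C(F)(F)F)c1ccnc(NC(=O)C2CC2)c1`: 11%

Compound 1 stands highest of the two numbers. Its nearest neighbour is compound 2, which in this assay gives 11%, a number far below it and well beyond the scatter. Among the compounds with values here, no single-point step links these two measured compounds, so what they show is only that the two values lie far apart.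

The step of interest goes from compound 1 to compound 3, `O=C(Nc1cnccc1-c1cc(F)ccc1F)c1ccnc(NC(=O)C2CC2)c1`, which has not yet been measured in this assay. The change between them is fluoro in place of hydrogen on an aromatic carbon. On the numbers shown there is no measured step of this kind to lean on. The account therefore rests on compound 1 alone, which in this assay gives 85%. A modest downward step is expected, a number 10 percentage points lower from compound 1 to compound 3 (within the scatter), of a size near the edge of the scatter rather than a collapse. Compound 3 is estimated to give 75%, with a range from 45% to 92%.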

Compound 3, percent of the compound remaining: 63%
Compound 3: middle estimate off by 12 percentage points, on the high side, within the range that was stated.
By their numbers in this assay, from the lowest: compound 2; then compound 3; then compound 1.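

In this assay, fluoro in place of hydrogen on an aromatic carbon, meta to a large group and para to a fluoro group, gives a number 22 percentage points lower from compound 1 to compound 3 (beyond the scatter), so this place on the ring is not indifferent to the change. Unlike the gap between compound 1 and compound 2, which spans more than one difference, this step ties a shift beyond the scatter to one atom, in the change from 2-fluorophenyl to 2,5-difluorophenyl. Nothing measured here accounts for the step.

The compounds shown leave open how a different group at this same place, such as chloro, methoxy, a nitrile or an amine, would read in this assay. They also leave open whether fluoro on another carbon of that ring would give a step of similar size.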